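The compounds below may be only part of what the source reports. "The series", "measured", "known", "first", "only" and "open" are said of these compounds alone.

In an ADME assay on HEK-293T cells (Homo sapiens) for cytotoxicity, read by CCK-8 assay, with a stated time of 48 h (on this read-out higher numbers stand for weaker inhibition and lower numbers for stronger inhibition), compound 1 `Nc1ccc(Oc2ccccc2-c2ccc(S(=O)(=O)NCCNC(=O)Nc3ccc(Cl)cc3)s2)cc1` gives > 20000 nM, which is a limit and not a number. Within the data shown here, compound 2 `O=C(NCCNS(=O)(=O)c1ccc(-c2ccccc2O[C@H]2CC[C@@H](O)CC2)s1)Nc1ccc([N+](=O)[O-])cc1` stands at 8600 nM, the only actual number so far. Compound 3 `O=C(NCCNS(=O)(=O)c1ccc(-c2ccccc2O[C@H]2CC[C@H](O)CC2)s1)Nc1ccc([N+](=O)[O-])cc1` departs from compound 2 in configuration alone: the two compounds have the same atoms and bonds and differ only in configuration as drawn: 2 of 2 stereo elements differ (all stereocentres are inverted: mirror images); a stereocentre at a saturated ring carbon is drawn s in compound 2 and r in compound 3; a stereocentre at a saturated ring carbon is drawn s in compound 2 and r in compound 3. Among the measured compounds shown here, no measured step in this assay covers such a change, so no shift beyond the scatter is expected, in either direction. The estimated step is a 1.0-fold higher number from compound 2 to compound 3 (0.02 log units; within the scatter). For compound 3 the expected value is 9000 nM, with an estimated range from 4500 nM to 18000 nM.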

Compound 3, half-maximal inhibitory concentration: 9000 nM
Compound 3: the middle estimate sits on the measured number at the digits printed; the range from low to high includes it.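

In this assay, drawing both stereocentres at the saturated ring carbons the opposite way gives a 1.0-fold higher number from compound 2 to compound 3 (0.02 log units; within the scatter). Among these compounds, this is the first readable step, so configuration at these two carbons leaves the read-out within the scatter for this pair. The comparison isolates that single feature: the fact that compounds 2 and 3 differ only in the configuration as drawn

As far as these compounds go, whether an amine or a carboxylic acid in place of the hydroxyl on the saturated ring would move the number remains open. Compound 1 gives > 20000 nM, which is a limit and not a number, and it differs from compound 2 in more than one place.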